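This account rests on a few compounds, and the source may have more. Where it says the series, first, only, none or still open, it means among the compounds named here.

Measured compounds
Compound 1: `O=S(=O)(NCC1CCN(CCCc2c[nH]c3ccc(-n4cnnc4)cc23)CC1)c1ccccc1` — in an assay on CHO cells for displacement of a labelled ligand from 5-hydroxytryptamine receptor 1B (Homo sapiens) (a lower number here means a stronger inhibitor, a higher number a weaker inhibitor), compound 1 gives 60 nM.
Compound 2: `CC(C)=CCCN(C)C1CCN(CCCc2c[nH]c3ccc(-n4cnnc4)cc23)CC1` — in this assay compound 2 gives 24 nM.

Within the data shown here, compound 2 holds the lowest of the two numbers in this assay; its nearest neighbour is compound 1, and the only measured step within the pair, a 2.5-fold lower number from compound 1 to compound 2 (0.40 log units; beyond the scatter), lies beyond the scatter and is modest in size.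

Compound 3 is `CN(C1CCN(CCCc2c[nH]c3ccc(-n4cnnc4)cc23)CC1)S(=O)(=O)c1ccccc1`. It differs from compound 2 in one place: phenylsulfonyl in place of 4-methylpent-3-en-1-yl on an amine nitrogen. This change reinstates the phenylsulfonyl group that compound 1 carries, though attached directly to the amine nitrogen rather than through the linking carbon seen in compound 1, and it keeps the methyl on that nitrogen.

Among the measured compounds shown here, the only step that bears on this is a 2.5-fold lower number from compound 1 to compound 2 (0.40 log units; beyond the scatter), which shows that exchanging the phenylsulfonyl-bearing group for the methyl(4-methylpent-3-en-1-yl)amino group gave a modestly lower number. Undoing most of that exchange in compound 3 is expected to give back a number of roughly that size, in the upward direction: the step of a 2.1-fold higher number from compound 2 to compound 3 (0.32 log units; beyond the scatter) is the expected outcome. Compound 3 is therefore estimated at 50 nM in this assay, with a range of 20 nM to 150 nM.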

Compound 3, half-maximal inhibitory concentration: 10 nM
For compound 3 the middle estimate is 5.0-fold (0.70 log units) above the measured one; the whole stated range lies above it.
By their numbers in this assay, from the lowest: compound 3; then compound 2; then compound 1.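

In this assay the step of a 2.4-fold lower number from compound 2 to compound 3 (0.38 log units; beyond the scatter) shows that phenylsulfonyl on this amine nitrogen gives a lower number than 4-methylpent-3-en-1-yl, so the higher number of compound 1 cannot be laid on the phenylsulfonyl group alone. The way that group is attached carries more weight in this small set: with methyl(phenylsulfonyl)amino in place of ((phenylsulfonyl)amino)methyl on a saturated ring carbon, the step of a 6.0-fold lower number from compound 1 to compound 3 (0.78 log units; beyond the scatter) is the largest of the three steps among these compounds. Compound 3 now holds the lowest number of the series, with both of its steps beyond the scatter, and nothing available explains the order of the three compounds.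

The step from compound 1 to compound 3 moves two things at once, the linking carbon and the methyl on the nitrogen, and the compounds shown do not separate their shares. Also open, on these data alone, is whether the low number depends on the sulfonyl link or on the phenyl ring, which a benzoyl group or a methylsulfonyl group on the same nitrogen would test.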